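Dinitrobenzamide cytotoxicity series: chloro to nitro on the anilide

The source may hold more compounds than are shown below. What is called first, only, known or untested is meant among the compounds shown, and "the series" means these compounds.

Measured compounds:
compound 1, `CN(C)c1c([N+](=O)[O-])cc(C(=O)Nc2ccc(Cl)cc2)cc1[N+](=O)[O-]`, 43200 nM
compound 2, `CCCCN(CCCC)c1c([N+](=O)[O-])cc(C(=O)Nc2ccc(Cl)cc2)cc1[N+](=O)[O-]`, 17100 nM

Among the compounds with values here, in an ADME assay on HUVEC cells (Homo sapiens) for cytotoxicity, read by MTT assay, with a stated time of 48 h (a lower number here means a stronger inhibitor, a higher number a weaker inhibitor), compound 2 gives the lower of the two numbers so far; its nearest neighbour is compound 1, and the only measured step is a 2.5-fold lower number from compound 1 to compound 2 (0.40 log units; beyond the scatter), a change at the amine on the shared core.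

Compound 3, `CCCCN(CCCC)c1c([N+](=O)[O-])cc(C(=O)Nc2ccc([N+](=O)[O-])cc2)cc1[N+](=O)[O-]`, keeps the dibutylamino group of compound 2 and differs only at the anilide: nitro in place of chloro on an aromatic carbon.

Within the data shown here, no measured step touches the anilide position, so nothing measured bears directly on this change. Among the measured compounds shown here, the single step on hand, a 2.5-fold lower number from compound 1 to compound 2 (0.40 log units; beyond the scatter), concerns the other end of the molecule and says nothing about swapping chloro for nitro here. In the absence of any guide, the expectation for this assay is no shift beyond the scatter: the estimated step of a 1.0-fold lower number from compound 2 to compound 3 (0.00 log units; within the scatter) is essentially flat. Compound 3 is therefore expected to come in near 17000 nM, with a wide range from 6000 nM to 50000 nM reflecting the lack of precedent.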

Compound 3, half-maximal inhibitory concentration: 19700 nM
Beside the measured number, compound 3's estimate is 1.2-fold (0.06 log units) below it; low and high end bracket the measured number.
By their numbers in this assay, from the lowest: compounds 2 and 3 (each within the scatter of the next); then compound 1.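

In this assay, the anilide position now has its first reading: with the dibutylamino group held fixed, nitro in place of chloro, para to a large group, gives a 1.2-fold higher number from compound 2 to compound 3 (0.06 log units; within the scatter), so compound 2 and compound 3 cannot be told apart. The step at the amine, a 2.5-fold lower number from compound 1 to compound 2 (0.40 log units; beyond the scatter), lies beyond the scatter while the step at the anilide does not, so among the compounds shown only the amine end has moved the number beyond the scatter. Nothing on hand explains why chloro and nitro read alike here.

From the compounds shown here alone, this reading rests on a single pair carrying the dibutylamino group, so it remains open whether chloro and nitro would also read alike with the dimethylamino group of compound 1. The compounds shown also leave open how the number responds to an amine or a carboxylic acid in that same place on the anilide, or to a longer chain on the amine at the other end of the molecule.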